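A few compounds are considered here, and "the series" means these few. Any claim that something is new, unique, unknown or untested is made for them only; others in the source may bear on it.

Measured compounds:
compound 1 `Nc1nn(C(=O)Nc2ccc(Cc3ccccc3)cc2)c2ccccc12` — "not determined" (no result reported) in a functional assay on NCI/ADR-RES cells (Homo sapiens) for antiproliferative activity, read by sulforhodamine B assay, with a stated time of 48 h; a lower number here means a stronger inhibitor of growth, a higher number a weaker inhibitor of growth
compound 2 `Nc1nn(C(=O)Nc2ccc(Cc3ccccc3)cc2)c2ccc(Cl)cc12` — 11000 nM in this assay

Within the data shown here, compound 2 holds the only number in this assay; compound 1 shares the whole of its structure apart from the chloro group on the core, yet has no result to set beside it. Compound 2 therefore stands alone, and its value marks it as a weak inhibitor of growth.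

Compound 3 `Nc1ccc2c(c1)c(N)nn2C(=O)Nc1ccc(Cc2ccccc2)cc1` keeps the benzyl-bearing urea side of the molecule and the shared core and differs from compound 2 in one place: amino in place of chloro on an aromatic carbon. Among the measured compounds shown here, no pair of measured compounds shows what this change does here, so the direction of the step is open. The expectation is a small step, a 1.4-fold higher number from compound 2 to compound 3 (0.13 log units; within the scatter), not clearly beyond the scatter in either direction. Compound 3 is therefore estimated at 15000 nM, within a range of 4000 nM to 50000 nM.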

Compound 3, concentration for 50% growth inhibition: 17400 nM
Estimate against measurement, compound 3: 1.2-fold (0.06 log units) below; low and high end bracket the measured number.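

In this assay amino in place of chloro on this aromatic carbon gives a 1.6-fold higher number from compound 2 to compound 3 (0.20 log units; within the scatter) and so does not separate the two groups. Compound 3 therefore remains a weak inhibitor of growth, like compound 2, although amino brings 1 hydrogen-bond donor and 1 hydrogen-bond acceptor where chloro has none. Nothing measured here offers a reason for this outcome.

Compound 1 has no number, so the pair cannot show what either group does compared with plain hydrogen on this carbon. From the compounds shown here alone, it also remains open whether a quite different group here, such as a methoxy group, a nitrile or a carboxylic acid, would stay level with chloro and amino or move growth inhibition beyond the scatter.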